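A few compounds are considered here, and "the series" means these few. Any claim that something is new, unique, unknown or untested is made for them only; others in the source may bear on it.

Measured compounds:
- Compound 1, `CC(C)(C)[C@@H](O)C(=O)N1[C@@H]2C[C@@H]2C[C@H]1C(=O)NCc1cc(Cl)ccc1-n1cnnn1`, in a functional assay on a cell-free system (plasma, Homo sapiens), with a stated time of 3 min (on this read-out higher numbers stand for weaker inhibition and lower numbers for stronger inhibition), compound 1 gives 1100 nM.
- Compound 2, `CC(C)(C)[C@@H](O)C(=O)N1[C@H](C(=O)NCc2cc(Cl)ccc2-n2cnnn2)C[C@@H]2C[C@@H]21`, in this assay compound 2 gives 1500 nM.
- Compound 3, `CC(C)(C)OC[C@@H](O)C(=O)N1N=CC[C@H]1C(=O)NCc1cc(Cl)ccc1-n1cnnn1`, in this assay compound 3 gives 750 nM.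

Compound 1 stands second highest of the three numbers. Its nearest neighbour is compound 2, reached by a 1.4-fold higher number from compound 1 to compound 2 (0.13 log units; within the scatter), a step within the scatter that rests on (the fact that compounds 1 and 2 differ only in the configuration as drawn). Compound 3 lies furthest from compound 1, yet that gap too is within the scatter, and compound 3 differs from compound 1 in more than one place, so only the two values themselves can be compared.

The unmeasured compound 4, `CC1(C[C@@H](O)C(=O)N2[C@@H]3C[C@@H]3C[C@H]2C(=O)NCc2cc(Cl)ccc2-n2cnnn2)CC1`, differs from compound 1 by (1-methylcyclopropyl)methyl in place of tert-butyl on a saturated chain carbon bound to a carbonyl carbon and an oxygen on a saturated carbon. Going by the values given here, no measured step touches this position; the only step on record, from compound 1 to compound 2, concerns configuration alone and is within the scatter. Nothing therefore points to a shift beyond the scatter in this assay. Compound 4 is expected to give about 1100 nM, between 400 nM and 3000 nM, so that the estimated step of no change at the digits printed from compound 1 to compound 4 (within the scatter) stays within the scatter.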

Compound 4, half-maximal inhibitory concentration: 1300 nM
For compound 4 the middle estimate is 1.2-fold (0.07 log units) below the measured one, within the range that was stated.
By their numbers in this assay, from the lowest: compounds 3, 1, 4 and 2 (each within the scatter of the next).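

Going by these compounds alone, the step to compound 4 gives the first reading at this position, on a saturated chain carbon bound to a carbonyl carbon and an oxygen on a saturated carbon: in this assay, (1-methylcyclopropyl)methyl in place of tert-butyl gives a 1.2-fold higher number from compound 1 to compound 4 (0.07 log units; within the scatter). The earlier compounds could not show this, as their only listed step concerned configuration alone. It shows that, for this one exchange, a carbon-only group carrying a three-membered non-aromatic ring is read the same as tert-butyl in this assay, and nothing on record bears on why.

The compounds shown leave open whether an amine, a carboxylic acid or a longer chain at this place would also stay within the scatter of compound 1. They also leave open whether the same exchange would read alike on the configuration of compound 2.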